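This account rests on a few compounds, and the source may have more. Where it says the series, first, only, none or still open, it means among the compounds named here.

Within the data shown here, compound 2 `COc1ccc(C(=O)c2sc(Nc3ccccc3)c(C(=O)O)c2C)cc1` gives 36.5% in a functional assay, with a stated time of 150 min, tested at 15 ug/mL (a higher number here means a stronger effect of the compound at the concentration tested, a lower number a weaker effect), and stands highest of the two numbers so far; compound 1 `COC(=O)c1c(Nc2ccccc2)sc(C(=O)c2ccc(OC)cc2)c1C` gives 28.6% in this assay, and the step of a number 7.9 percentage points higher from compound 1 to compound 2 (within the scatter) lies within the scatter, so the two are level. Compound 3 `COc1ccc(C(=O)c2sc(Nc3ccc(Cl)cc3)c(C(=O)O)c2C)cc1` differs from compound 2 by chloro in place of hydrogen on an aromatic carbon. Among the measured compounds shown here, no measured step touches the anilino group; the only recorded step, a number 7.9 percentage points higher from compound 1 to compound 2 (within the scatter), concerns hydrogen in place of methyl on an oxygen next to a carbonyl group and does not bear on this change. For compound 3 the expected step is therefore a number 3.5 percentage points higher from compound 2 to compound 3 (within the scatter), with no direction beyond the scatter. Compound 3 is estimated at 40%, in the range 22% to 60%.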

Compound 3, a percentage reported as activity, at one concentration (the size of the read-out at that concentration, not a potency): "not active" (no number reported)
Compound 3: no number reported; there is nothing to compare the estimate with.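

Among these compounds, compound 3 is reported as "not active" without a number, so no step from compound 2 to compound 3 can be read. The compounds shown leave open how far phenyl to 4-chlorophenyl shifts the read-out. No other data bear on this result.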